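Chloro for fluoro on the anilino ring of compound 3

The compounds below may be only part of what the source reports. "The series", "measured", "known", "first", "only" and "open" are said of these compounds alone.

Compound 3 `COc1cc(-c2nn(-c3ccccc3)cc2C(=O)/C=C\Nc2ccc(F)cc2)cc(OC)c1OC` was tested in a functional assay on PC-3 cells (Homo sapiens) for antiproliferative activity, read by MTT assay, with a stated time of 48 h (a higher number here means a weaker inhibitor, a lower number a stronger inhibitor), where compound 3 gives 7700 nM. Among the three compounds with numbers, compound 3 has the highest. Compound 1 `O=C(/C=C\Nc1ccc(O)cc1)c1cn(-c2ccccc2)nc1-c1ccc(F)cc1` gives 2600 nM, and compound 2 `O=C(/C=C\Nc1ccc(O)cc1)c1cn(-c2ccccc2)nc1-c1ccc(Cl)cc1` gives 4430 nM; the gap from compound 3 to compound 2 is within the scatter, while the gap to compound 1 lies beyond it.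

Compound 4 `COc1cc(-c2nn(-c3ccccc3)cc2C(=O)/C=C\Nc2ccc(Cl)cc2)cc(OC)c1OC` is not yet measured. It differs from compound 3 in one place: chloro in place of fluoro on an aromatic carbon. Among the measured compounds shown here, the only measured step of the same kind is a 1.7-fold higher number from compound 1 to compound 2 (0.23 log units; within the scatter), where the exchange sat on the aryl ring attached to the shared core rather than on the anilino ring. For the measured compounds named here, that step stayed within the scatter, and no step on the anilino ring itself is known.

On that basis, compound 4 is expected to show a step of a 1.2-fold higher number from compound 3 to compound 4 (0.09 log units; within the scatter), with no movement beyond the scatter clearly indicated. The estimate for compound 4 in this assay is 9500 nM, within a range from 4000 nM to 22000 nM.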

Compound 4, half-maximal inhibitory concentration: 11200 nM
Compound 4: middle estimate off by 1.2-fold (0.07 log units), on the low side, within the range that was stated.
By their numbers in this assay, from the lowest: compounds 1, 2, 3 and 4 (each within the scatter of the next, the first and the last beyond it).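

The earlier compounds shown here showed this exchange only on the aryl ring attached to the shared core, and now it can be read on the anilino ring as well. In this assay, the exchange gives a 1.5-fold higher number from compound 3 to compound 4 (0.16 log units; within the scatter), so at this position fluoro and chloro cannot be told apart in this read-out. The exchange also reads alike in the two places: the same change on two cores in this assay, a 1.7-fold higher number (0.23 log units; within the scatter) from compound 1 to compound 2 and a 1.5-fold higher number (0.16 log units; within the scatter) from compound 3 to compound 4, 1.2-fold (0.07 log units) apart, within the scatter of two such steps

Because only these two halogens can be compared at this position, the compounds shown leave open whether a bromo group, a methyl group, an amine or a carboxylic acid in the same place would move the number beyond the scatter. They also leave open whether the exchange would read the same elsewhere on the anilino ring.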